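Swapping dimethylamino for hydroxy on two different cores

A few compounds are considered here, and "the series" means these few. Any claim that something is new, unique, unknown or untested is made for them only; others in the source may bear on it.

Compound 1 `COc1ccc(C(=O)c2ccc(OC)c3c2OC(C)(C)C=C3)c(NC(=O)CO)c1`, compound 2 `COc1ccc(C(=O)c2ccc(OC)c3c2OC(C)(C)C=C3)c(NC(=O)CN(C)C)c1` and compound 3 `C=C(c1cc(OC)c(OC)c(OC)c1)c1ccc(OC)c(O)c1NC(=O)CN(C)C` were all tested in a functional assay on A2780 cells (Homo sapiens) for antiproliferative activity, read by MTT assay, with a stated time of 48 h; on this read-out lower numbers stand for stronger inhibition and higher numbers for weaker inhibition. In this assay compound 1 gives 100 nM, while compound 2 gives 790 nM. Compound 1 and compound 2 share one core and differ in a single spot: hydroxy in place of dimethylamino on a saturated chain carbon bound to a carbonyl carbon. That one change produced a 7.9-fold lower number from compound 2 to compound 1 (0.90 log units; beyond the scatter). Compound 3 is built on another core, and the difference between the two cores is not broken down here. In this assay compound 3 gives 90 nM, a number close to that of compound 1 and well apart from that of compound 2.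

Compound 4 `C=C(c1cc(OC)c(OC)c(OC)c1)c1ccc(OC)c(O)c1NC(=O)CO` has not yet been measured. It differs from compound 3 in the same way that compound 1 differs from compound 2: hydroxy in place of dimethylamino on a saturated chain carbon bound to a carbonyl carbon. Since the place of the change is the same on both cores, the same change is expected to move the number in the same direction, although its size on a new core is uncertain and compound 3 already sits low. The expected step is a 3.6-fold lower number from compound 3 to compound 4 (0.56 log units; beyond the scatter), resting on a 7.9-fold lower number from compound 2 to compound 1 (0.90 log units; beyond the scatter). Compound 4 is therefore estimated at 25 nM, with a plausible range from 7 nM to 90 nM.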

Compound 4, half-maximal inhibitory concentration: 20 nM
Beside the measured number, compound 4's estimate is 1.3-fold (0.10 log units) above it, within the range that was stated.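

In this assay, putting hydroxy in place of dimethylamino on the core of compound 3 gave a 4.5-fold lower number from compound 3 to compound 4 (0.65 log units; beyond the scatter), so the number fell on this second core as it had on the first. Set side by side, the two steps cannot be told apart in size: the same change on two cores in this assay, a 7.9-fold lower number (0.90 log units; beyond the scatter) from compound 2 to compound 1 and a 4.5-fold lower number (0.65 log units; beyond the scatter) from compound 3 to compound 4, 1.8-fold (0.24 log units) apart, within the scatter of two such steps

This shows that, for these two pairs of compounds, the change carried from one core to the other in both direction and approximate size, but two pairs in a single cell assay do not establish a general rule for the series, and they do not explain why the number fell.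

The compounds shown carry only hydroxy or dimethylamino at this place, so it remains open how a primary amine, a carboxylic acid or a longer chain ending in hydroxy would compare. On these data alone, it also remains open whether the same step would appear on a third core or in another cell line.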